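Shortening a Dimethylamino Chain on a Sulfamate Amide

A few compounds are considered here, and "the series" means these few. Any claim that something is new, unique, unknown or untested is made for them only; others in the source may bear on it.

All compounds here share a core bearing a sulfamate group and an amide. In an assay on HEK293 cells for inhibition of Steryl-sulfatase (Homo sapiens), tested at 0.1 uM (on this read-out lower numbers stand for a weaker effect and higher numbers for a stronger effect at the one concentration tested), compound 1, `CN(C)CCCN(Cc1ccccc1)c1ccc(C(=O)N2CCc3ccc(OS(N)(=O)=O)cc3C2)cc1`, gives 16.2%. Compound 2, `NS(=O)(=O)Oc1ccc2c(c1)CN(C(=O)c1cccc(N3CCc4ccccc4C3)c1)CC2`, gives 24.1% in this assay, and compound 3, `NS(=O)(=O)Oc1ccc2c(c1)CN(C(=O)c1cccc(N(CCCO)Cc3ccccc3)c1)CC2`, gives 25.8%. Compound 1 stands at the smallest of the three numbers, yet its gaps to compound 2 and to compound 3 both fall within the usual scatter, so the three cannot be told apart on these readings.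

Compound 4, `CN(C)CCN(Cc1ccccc1)c1ccc(C(=O)N2CCc3ccc(OS(N)(=O)=O)cc3C2)cc1`, differs from compound 1 in a single place: dimethylamino in place of (dimethylamino)methyl on a saturated chain carbon, two bonds along the chain from a nitrogen on an aromatic ring. The basic nitrogen stays, the chain that carries it is one carbon shorter. Among the compounds with values here, no pair of measured compounds shows what such a shortening does, so nothing measured points in either direction. A step from compound 1 to compound 4 that stays within the scatter is therefore expected, of about a number 1.8 percentage points higher from compound 1 to compound 4 (within the scatter). On that basis compound 4 is estimated to give 18% in this assay, most likely between 8% and 32%.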

Compound 4, a percentage reported as inhibition, at one concentration (the size of the read-out at that concentration, not a potency): 13.9%
Compound 4: the middle estimate sits 4.1 percentage points above what was measured, and the stated range covers the measured number.
By their numbers in this assay, from the lowest: compounds 4, 1, 2 and 3 (each within the scatter of the next, the first and the last beyond it).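

Cutting the chain from 3-(dimethylamino)propyl to 2-(dimethylamino)ethyl gives a number 2.3 percentage points lower from compound 1 to compound 4 (within the scatter) in this assay. Within the data shown here, this is the first pair of measured compounds that differ in only one place, and it shows that at this position, at the one concentration tested, compound 1 and compound 4 cannot be told apart, so the length of this chain has no readable effect across these two compounds. Nothing measured here offers an explanation for this reading.

From the compounds shown here alone, it remains open whether a longer chain, such as 4-(dimethylamino)butyl, or a chain ending in a carboxylic acid instead of dimethylamino, would read differently at this position. A single concentration also leaves open whether compound 1 and compound 4 would separate at other concentrations.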